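Adding a 2-Hydroxyethyl Arm to Compound 2

A few compounds are considered here, and "the series" means these few. Any claim that something is new, unique, unknown or untested is made for them only; others in the source may bear on it.

Measured so far:
Compound 1, `CCCCCCc1cn(C(c2ccccc2)c2cc3cc(Br)ccc3nc2OC)nn1`, gives 7.17% in an ADME assay on SK-OV-3 cells (Homo sapiens) for cytotoxicity, read by sulforhodamine B assay, with a stated time of 48 h, tested at 10 uM; a lower number here means less inhibition, a higher number more inhibition at the concentration tested (going by the name of the read-out).
Compound 2, `CCCc1cn(C(c2ccccc2)c2cc3cc(Br)ccc3nc2OC)nn1`, gives 11.2% in this assay.

Among these two numbers compound 2 stands highest, but its nearest neighbour is compound 1, and the gap between them lies within the usual scatter, so the two cannot be told apart. Among the compounds with values here, the only step seen so far, a number 4 percentage points higher from compound 1 to compound 2 (within the scatter), replaced hydrogen in place of propyl on a saturated chain carbon, three bonds along the chain from an aromatic carbon, and it changed nothing beyond the scatter.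

Compound 3, `COc1nc2ccc(Br)cc2cc1C(c1ccccc1)n1cc(CCCCCO)nn1`, differs from compound 2 by 2-hydroxyethyl in place of hydrogen on a saturated chain carbon, three bonds along the chain from an aromatic carbon. Within the data shown here, that change also lengthens the same chain, now with a hydroxyl at its end, a difference no measured pair covers. Among the measured compounds shown here, since the one chain-length step stayed within the scatter, compound 3 is expected to sit near compound 2, with a number 1.2 percentage points lower from compound 2 to compound 3 (within the scatter), at about 10% (range 0% to 22%).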

Compound 3, a percentage reported as inhibition, at one concentration (the size of the read-out at that concentration, not a potency): 8.69%
The estimate for compound 3 lay 1.3 percentage points above the measured number; the range from low to high includes it.
By their numbers in this assay, from the lowest: compounds 1, 3 and 2 (each within the scatter of the next).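

In this assay, adding the 2-hydroxyethyl arm on a saturated chain carbon, three bonds along the chain from an aromatic carbon, gives a number 2.5 percentage points lower from compound 2 to compound 3 (within the scatter) and so leaves the read-out unchanged beyond the scatter. Placing hydroxy in place of methyl on a saturated chain carbon, five bonds along the chain from an aromatic carbon, gives a number 1.5 percentage points higher from compound 1 to compound 3 (within the scatter) and so shows that a hydroxyl at the chain end can be carried here without a change that can be told from the scatter. No supporting data are available to explain this flat result.

On these data alone, whether an amine or a carboxylic acid at the end of this chain would shift the number stays open. So does whether a much longer chain would behave any differently.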